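A few compounds are considered here, and "the series" means these few. Any claim that something is new, unique, unknown or untested is made for them only; others in the source may bear on it.

The series shares one core. Compound 1 is `CNC(=O)c1cc(Oc2ccc3nc(Nc4cccc(C(C)(C)C)c4)ncc3c2)ccn1`, compound 2 is `CNC(=O)c1cc(Oc2ccc3nc(Nc4ccccc4Br)ncc3c2)ccn1` and compound 3 is `CNC(=O)c1cc(Oc2ccc3nc(Nc4cccc(C(C)C)c4)ncc3c2)ccn1`. In a physicochemical assay for solubility, at pH 7 (a higher number here means a more soluble compound, a lower number a less soluble compound), compound 1 gives < 1000 nM, which is a limit of the assay rather than a number. In this assay compound 2 gives < 1000 nM, again a limit. In this assay compound 3 gives < 1000 nM, also a limit. Compound 3 therefore stands only at a limit, and all three measured compounds sit together at the limit of < 1000 nM in this assay, at which 3 of the 3 values shown sit. The three steps among them, a step that the two limits leave unreadable from compound 1 to compound 2, a step that the two limits leave unreadable from compound 1 to compound 3 and a step that the two limits leave unreadable from compound 2 to compound 3, carry no readable size.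

The unmeasured compound 4 is `CNC(=O)c1cc(Oc2ccc3nc(Nc4ccc(OC(F)(F)F)cc4)ncc3c2)ccn1`, and it differs from compound 3 by 4-(trifluoromethoxy)phenyl in place of 3-isopropylphenyl on a nitrogen on an aromatic ring. Among the compounds with values here, the steps that bear on this change are the same three, none of which can be read, so nothing anchors the size or direction of the step in this assay beyond the fact that every measured value sits at the limit. The step that the estimate implies is expected to be a step that the limit leaves unreadable from compound 3 to compound 4, with no direction claimed beyond the scatter. For compound 4 the estimate in this assay is 600 nM, with a range from 150 nM to 2500 nM.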

Compound 4, solubility: < 1000 nM
Compound 4 gave a limit, no number (the forecaster's own chance of this, stated with the estimate: 70%); the middle value lies beyond the limit too.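

The steps to compound 4 from compound 1, compound 2 and compound 3 cannot be read in this assay, and the compounds stand together at one limit of the assay: the limit of < 1000 nM in this assay, at which 4 of the 4 values shown sit. The compounds shown leave open how far apart these four truly lie in this assay, and whether any group at this nitrogen would give a readable number.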